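Adding a Bromo Group to Compound 1

A few compounds are considered here, and "the series" means these few. Any claim that something is new, unique, unknown or untested is made for them only; others in the source may bear on it.

Measured in a functional assay on A549 cells (Homo sapiens) for antiproliferative activity, read by MTT assay, with a stated time of 48 h; on this read-out higher numbers stand for weaker inhibition of growth and lower numbers for stronger inhibition of growth:
Compound 1 `COc1ccc(/C=C2\Cc3c(cc(OC)c(OC)c3OC)C2=O)cc1`: 273 nM
Compound 2 `COc1cc(/C=C2\Cc3c(cc(OC)c(OC)c3OC)C2=O)cc(OC)c1OC`: 2790 nM
Compound 3 `COc1cc2c(c(OC)c1OC)C/C(=C\c1cc(OC)c(OC)c(OC)c1OC)C2=O`: > 10000 nM, a limit of the assay and not a number

Among the two true numbers, compound 1 holds the lower one, and compound 2 lies higher by more than the usual scatter. Compound 4 `COc1ccc(/C=C2\Cc3c(cc(OC)c(OC)c3OC)C2=O)cc1Br` is compound 1 with a single change: bromo in place of hydrogen on an aromatic carbon. Bromo replaces hydrogen on an aromatic carbon, ortho to a methoxy group. For the measured compounds named here, no measured step shows what bromo itself does in this assay. The closest guide is a swap of a different group, methoxy in place of hydrogen on an aromatic carbon, which gave an at least 3.5-fold higher number from compound 2 to compound 3 (0.55 log units; beyond the scatter). That step ran towards weaker inhibition of growth, so a loose expectation is a rise of modest size, although no change beyond the scatter remains possible. The expected change is a 2.2-fold higher number from compound 1 to compound 4 (0.34 log units; beyond the scatter). Compound 4 is estimated at 600 nM, with an expected range from 150 nM to 3000 nM.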

Compound 4, concentration for 50% growth inhibition: 410 nM
Compound 4: the middle estimate sits 1.5-fold (0.17 log units) above what was measured; low and high end bracket the measured number.
By their numbers in this assay, from the lowest: compounds 1 and 4 (each within the scatter of the next); then compound 2. At a limit, above all of these: compound 3.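

In this assay, for the compounds shown here, bromo in place of hydrogen, on an aromatic carbon ortho to a methoxy group, gives a 1.5-fold higher number from compound 1 to compound 4 (0.18 log units; within the scatter) and so offers the first direct reading at this position. Going by these compounds alone, the only earlier step, an at least 3.5-fold higher number from compound 2 to compound 3 (0.55 log units; beyond the scatter) for methoxy in place of hydrogen, concerned another group on another compound, so it could not show that this carbon accepts a single bromine atom with no difference from compound 1 beyond the scatter. Nothing shown explains this outcome beyond the numbers themselves.

The compounds shown leave open how this same carbon responds to a group of another kind, such as an amine, a carboxylic acid or a longer chain. They also leave open whether bromo gives a similar result on the other aromatic carbons of compound 1.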